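The source may report more compounds than this note shows. Statements on the series, on what has been measured and on what is new or still open speak of the compounds shown alone.

Measured compounds:
compound 1 `COc1cc2c(Oc3ccc(NC(=O)N/N=C/c4ccc([N+](=O)[O-])cc4)cc3F)ccnc2cc1OCCCN1CCC(C)CC1` gives 870 nM
compound 2 `COc1cc2c(Oc3ccc(NC(=O)N/N=C/c4ccc(C(F)(F)F)cc4)cc3F)ccnc2cc1OCCCN1CCC(C)CC1` gives 1300 nM

Both values come from a functional assay on MDA-MB-231 cells (Homo sapiens) for cytotoxicity, read by MTT assay, with a stated time of 72 h; on this read-out higher numbers stand for weaker inhibition and lower numbers for stronger inhibition. Compound 2 holds the highest of the two numbers, and its nearest neighbour is compound 1, with a step of a 1.5-fold higher number from compound 1 to compound 2 (0.17 log units; within the scatter) between them; that step, which swaps a nitro group for a trifluoromethyl group on an aromatic carbon, is within the scatter, so no difference between compound 1 and compound 2 can be claimed.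

Compound 3 `COc1cc2c(Oc3ccc(NC(=O)N/N=C/c4ccc(Cl)cc4Cl)cc3F)ccnc2cc1OCCCN1CCC(C)CC1` has not been measured. It differs from compound 2 in one place: 2,4-dichlorophenyl in place of 4-(trifluoromethyl)phenyl on a carbon with a double bond to nitrogen. For the measured compounds named here, no measured step changes this part of the shared core in the same way, so the only step that bears on it is the one from compound 1 to compound 2, which varied the same aromatic ring and stayed within the scatter. Compound 3 is therefore expected to give a number near that of compound 2, with an estimated step of a 1.2-fold lower number from compound 2 to compound 3 (0.07 log units; within the scatter) in this assay. Compound 3 is estimated at 1100 nM, within a range of 400 nM to 3000 nM.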

Compound 3, half-maximal inhibitory concentration: 910 nM
The estimate for compound 3 lay 1.2-fold (0.08 log units) above the measured number; measured number inside the range.
By their numbers in this assay, from the lowest: compounds 1, 3 and 2 (each within the scatter of the next).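

In this assay, 2,4-dichlorophenyl in place of 4-(trifluoromethyl)phenyl gives a 1.4-fold lower number from compound 2 to compound 3 (0.15 log units; within the scatter) and, in place of 4-nitrophenyl, gives a 1.0-fold higher number from compound 1 to compound 3 (0.02 log units; within the scatter) on the same carbon with a double bond to nitrogen. The earlier step only exchanged one group on the ring, whereas this change brings a ring carrying two chlorine atoms, and still no difference among the three compounds can be claimed. Nothing measured here offers an explanation for this result.

The compounds shown leave open whether a phenyl ring carrying an amine or a carboxylic acid, or a cyclohexyl ring in place of the phenyl ring, would move the number beyond the scatter. As far as these compounds go, all three also share the rest of the structure, so the effect of changes elsewhere remains unknown.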